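Methoxy added to compound 3: expected effect on cytotoxicity

The source may hold more compounds than are shown below. What is called first, only, known or untested is meant among the compounds shown, and "the series" means these compounds.

Working notes on the series. Compound 1 `COc1ccc(-c2cc(/N=C3/NC(=O)CS3)cs2)cc1` gives > 50000 nM in a functional assay on SW-620 cells (Homo sapiens) for cytotoxicity, read by MTT assay, with a stated time of 72 h (a lower number here means a stronger inhibitor, a higher number a weaker inhibitor), which is a limit of the assay rather than a number. Compound 2 `O=C1CS/C(=N\c2csc(-c3ccccc3)c2)N1` likewise gives > 50000 nM, again a limit. Compound 3 `O=C1N/C(=N/c2csc(-c3ccc(Cl)cc3)c2)S/C1=C\c1ccccc1` gives > 50000 nM, also a limit. Thus (the limit of > 50000 nM in this assay, at which 3 of the 3 values shown sit); compound 3 stands with the other two at that limit, and no ordering among them can be read. Among the measured compounds shown here, the one step between measured compounds, a step that the two limits leave unreadable from compound 1 to compound 2, is the same exchange of methoxy and hydrogen as the one followed here but at a different place in the molecule, and its size cannot be read because both ends are limits. Compound 4 `COc1ccc(/C=C2\S/C(=N\c3csc(-c4ccc(Cl)cc4)c3)NC2=O)cc1` differs from compound 3 by methoxy in place of hydrogen on an aromatic carbon. For the measured compounds named here, no measured step gives a readable size for this change, so no shift beyond the scatter is expected in this assay; the expectation is that compound 4 also reports a limit. The step from compound 3 to compound 4 is expected to be a number no higher from compound 3 to compound 4 (the limit leaves the size open). Compound 4 is expected at 50000 nM, within a range from 20000 nM to 120000 nM.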

Compound 4, half-maximal inhibitory concentration: 28100 nM
Estimate against measurement, compound 4: 1.8-fold (0.25 log units) above; low and high end bracket the measured number.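

In this assay, methoxy in place of hydrogen on the aromatic carbon para to a large group gives an at least 1.7-fold lower number from compound 3 to compound 4 (0.25 log units; that floor lies within the scatter). Compound 4 is thus the only compound shown with a number rather than a limit, and this exchange is the only one with a readable floor, while the step elsewhere in the molecule cannot be read. The remaining compounds stay at a limit of the assay: the limit of > 50000 nM in this assay, at which 3 of the 4 values shown sit.

Going by these compounds, the true size of the step stays open, and the floor alone does not separate it from the scatter. Also open, on these data alone, is whether an amine, a carboxylic acid or a longer chain such as ethoxy at this position would give a number in this assay, and how such a number would compare with that of compound 4.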